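The compounds below may be only part of what the source reports. "The series", "measured", "known", "first", "only" and "open" are said of these compounds alone.

Measured so far in an ADME assay on microsomes from liver (Mus musculus) for metabolic stability, read by LC-MS, using NADPH, with a stated time of 10 min, tested at 0.1 uM; on this read-out higher numbers stand for fast clearance and lower numbers for slow clearance:
compound 1, `COc1ccccc1N1C(=O)CSC1c1cc(F)cc(C(=O)NCCCCc2ccccc2)c1`: 1430 mL.min-1.g-1
compound 2, `C#Cc1cc(C(=O)NCCCCc2ccccc2)cc(C2SCC(=O)N2c2ccccc2OC)c1`: 2490 mL.min-1.g-1
compound 3, `C#Cc1cccc(N2C(=O)CSC2c2cccc(C(=O)NCCCCc3ccccc3)c2)c1`: 1900 mL.min-1.g-1

All three numbers lie within the usual scatter of one another, so no order among them can be read from these data. One change is seen twice. From compound 2 to compound 1 it is fluoro in place of ethynyl on an aromatic carbon, and it gave a 1.7-fold lower number from compound 2 to compound 1 (0.24 log units; within the scatter). Compound 4, `O=C(NCCCCc1ccccc1)c1cccc(C2SCC(=O)N2c2cccc(F)c2)c1`, is not yet measured; it differs from compound 3 by fluoro in place of ethynyl on an aromatic carbon. The difference between the core of compound 3 and the core of compound 2 is not broken down here. The surroundings are not identical: in compound 2 the group sits meta to two large groups, in compound 3 meta to a large group, so this is the same kind of change rather than the same change. The expected step in this assay is a 1.7-fold lower number from compound 3 to compound 4 (0.22 log units; within the scatter), set beside a 1.7-fold lower number from compound 2 to compound 1 (0.24 log units; within the scatter). That expectation rests on compound 3, which gives 1900 mL.min-1.g-1, and on the earlier step. Compound 4 is therefore estimated at about 1150 mL.min-1.g-1, with a likely range from 600 mL.min-1.g-1 to 2200 mL.min-1.g-1.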

Compound 4, intrinsic clearance in microsomes: 2740 mL.min-1.g-1
Estimate against measurement, compound 4: 2.4-fold (0.38 log units) below; the measured number lies above the stated range.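

In this assay, fluoro in place of ethynyl gave a 1.4-fold higher number from compound 3 to compound 4 (0.16 log units; within the scatter). Set beside the same change on the other core, this step does not stand apart from the earlier one: the same change on two cores in this assay, a 1.7-fold lower number (0.24 log units; within the scatter) from compound 2 to compound 1 and a 1.4-fold higher number (0.16 log units; within the scatter) from compound 3 to compound 4, 2.5-fold (0.40 log units) apart, within the scatter of two such steps. So on both cores the change stays within what repeated measurements would show, which gives no sign that the core decides its outcome, but two small steps cannot show that it carries over in the same way, nor that it does not.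

The compounds shown hold only fluoro or ethynyl at these places. As far as these compounds go, whether a nitrile or an amine there, or a longer chain on the amide, would give a number beyond the scatter stays open.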